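Methyl on the Fused Core: Microsomal Half-Life Notes

The compounds below may be only part of what the source reports. "The series", "measured", "known", "first", "only" and "open" are said of these compounds alone.

Measured so far:
- compound 1 `CN1C(=O)COc2cc(Nc3cc4c(cn3)ncn4CC3CC3)cnc21`: in an ADME assay on microsomes from liver (Homo sapiens) for metabolic stability (a lower number here means that the compound disappears faster, a higher number that the compound lasts longer), compound 1 gives > 1.66 h, which is a limit of the assay, not a number.
- compound 2 `Cc1nc(Nc2cnc3c(c2)OCC(=O)N3C)cc2c1ncn2CC1CC1`: in this assay compound 2 gives > 1.66 h, again a limit of the assay.
- compound 3 `CN1C(=O)COc2cc(Nc3ccc4ncn(CC5CC5)c4n3)cnc21`: in this assay compound 3 gives 0.233 h, the only plain number in the set.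

Compound 1 and compound 2 share a core and differ by methyl in place of hydrogen on an aromatic carbon. The step that the two limits leave unreadable from compound 1 to compound 2 cannot be read, since both values sit at the limit of > 1.66 h in this assay, at which 2 of the 3 values shown sit. Compound 3 has the same atoms as compound 1, joined differently; the difference between the two cores is not broken down here.

Compound 4 `Cc1cc(Nc2cnc3c(c2)OCC(=O)N3C)nc2c1ncn2CC1CC1` is not yet measured. It differs from compound 3 by methyl in place of hydrogen on an aromatic carbon. This is the same kind of change as that from compound 1 to compound 2, not the same: there the methyl sits next to the ring nitrogen, here opposite the ring nitrogen. With the earlier step unreadable, the expectation for compound 4 rests on compound 3 alone, whose value 0.233 h is taken as the anchor. The step to compound 4 is estimated as a 1.3-fold higher number from compound 3 to compound 4 (0.11 log units; within the scatter), within the usual scatter. Compound 4 is therefore expected at 0.3 h, with a likely range of 0.12 h to 0.9 h.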

Compound 4, half-life: 0.483 h
Compound 4: the middle estimate sits 1.6-fold (0.21 log units) below what was measured, within the range that was stated.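

In this assay, methyl in place of hydrogen on an aromatic carbon, opposite the ring nitrogen, gives a 2.1-fold higher number from compound 3 to compound 4 (0.32 log units; beyond the scatter), so on the core of compound 3 this change goes with a modest gain in half-life. This is a single readable step on a single core, and it shows no general effect of methyl across the series. It also does not show that the change carries from one core to another, since the same kind of change on the core of compound 1 sits at another place and the step to compound 2 cannot be read, because compound 1 and compound 2 both stand at a limit of the assay: the limit of > 1.66 h in this assay, at which 2 of the 4 values shown sit.

From the compounds shown here alone, whether a larger or different group on that same aromatic carbon of the core of compound 3, such as ethyl, methoxy or an amine, would give a step of similar size remains open. The compounds shown also leave open how large the methyl step is on the core of compound 1.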